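A few compounds are considered here, and "the series" means these few. Any claim that something is new, unique, unknown or untested is made for them only; others in the source may bear on it.

Compound 1, `CCOC(=O)c1ccc(NC(=O)CSC(=S)N[C@H]2CCOC2=O)cc1`: in a functional assay on MCF7 cells (Homo sapiens) for cytotoxicity, read by MTT assay, with a stated time of 72 h (a higher number here means a weaker inhibitor, a lower number a stronger inhibitor), compound 1 gives 60300 nM.
Compound 2, `O=C(CSC(=S)N[C@H]1CCOC1=O)Nc1ccc(C(=O)/C=C/c2ccc(Br)cc2)cc1`: in this assay compound 2 gives 18700 nM.
Compound 3, `O=C(CSC(=S)N[C@H]1CCOC1=O)Nc1ccc(C(=O)/C=C/c2cccc(Cl)c2)cc1`: in this assay compound 3 gives 11600 nM.

Compound 3 has the lowest number of the three, but its distance to compound 2 is small: a 1.6-fold lower number from compound 2 to compound 3 (0.21 log units; within the scatter). Against compound 1 the gap is wider: a 5.2-fold lower number from compound 1 to compound 3 (0.72 log units; beyond the scatter), and likewise a 3.2-fold lower number from compound 1 to compound 2 (0.51 log units; beyond the scatter). Those two larger steps both replace the ethoxy group on a carbonyl carbon with a much bigger group, so they say little about what happens when only the aromatic ring on a double-bonded chain carbon bound to a double-bonded chain carbon is exchanged. Among the compounds with values here, the one step of that kind, from compound 2 to compound 3, stays within the scatter.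

Compound 4, `O=C(CSC(=S)N[C@H]1CCOC1=O)Nc1ccc(C(=O)/C=C/c2ccc([N+](=O)[O-])cc2)cc1`, is the next member. It differs from compound 3 in one place: 4-nitrophenyl in place of 3-chlorophenyl on a double-bonded chain carbon bound to a double-bonded chain carbon. This is the same sort of alteration as between compound 2 and compound 3, one substituted ring swapped for another at the same place, so no step beyond the scatter is expected here: a 1.1-fold lower number from compound 3 to compound 4 (0.02 log units; within the scatter). Compound 4 is therefore estimated at 11000 nM, with a range from 4500 nM to 28000 nM.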

Compound 4, half-maximal inhibitory concentration: 2670 nM
Beside the measured number, compound 4's estimate is 4.1-fold (0.61 log units) above it; measured number below the stated range.
By their numbers in this assay, from the lowest: compound 4; then compounds 3 and 2 (each within the scatter of the next); then compound 1.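

Swapping one substituted ring for another on a double-bonded chain carbon bound to a double-bonded chain carbon can move the number beyond the scatter in this assay, as a 4.3-fold lower number from compound 3 to compound 4 (0.64 log units; beyond the scatter) shows, something the earlier exchange of this kind did not show. Within the data shown here, the choice of group on the ring therefore counts here: with nitro in place of bromo on an aromatic carbon, the result is a 7.0-fold lower number from compound 2 to compound 4 (0.85 log units; beyond the scatter), and the 4-nitrophenyl compound also gives the only large step in the set, a 23-fold lower number from compound 1 to compound 4 (1.35 log units; beyond the scatter). Why nitro goes with the lowest number cannot be said, as nothing available here bears on the cause.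

The exchange of 3-chlorophenyl for 4-nitrophenyl alters both the group and its numbered place on the ring, so 3-nitrophenyl and 4-chlorophenyl are the comparisons that would separate those two changes. On these data alone, it also remains open whether the trend reaches beyond these rings, for example to a 4-aminophenyl or a 4-carboxyphenyl group at this place.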